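The compounds below may be only part of what the source reports. "The series", "measured", "known", "first", "only" and "open" are said of these compounds alone.

Of the compounds shown here, three of one shared core have been tested in a functional assay on PC-3 cells (Homo sapiens) for cytotoxicity, read by MTT assay, with a stated time of 72 h; on this read-out higher numbers stand for lower toxicity in this test and lower numbers for higher toxicity in this test. Compound 1 `C[Se]/C(=N\C(=O)c1cc2ccccc2s1)NC(=O)c1cc2ccccc2s1` is the only one of the three that gives a number: in this assay compound 1 gives 94000 nM. Compound 2 `C[Se]/C(=N\C(=O)c1sccc1Cl)NC(=O)c1sccc1Cl` reaches only the limit of the assay, giving > 100000 nM. Compound 3 `CS/C(=N\C(=O)c1ccco1)NC(=O)c1ccco1` likewise reaches only the limit, giving > 100000 nM. So compound 2 stands among the two of three compounds that sit at the limit, as the limit of > 100000 nM in this assay, at which 2 of the 3 values shown sit, shows, with no number of its own.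

The step to be followed leads from compound 2 to compound 4 `CS/C(=N\C(=O)c1sccc1Cl)NC(=O)c1sccc1Cl`, where the change is a group of 2 heavy atoms (1 carbon, 1 sulfur; no ring) in place of a group of 2 heavy atoms (1 carbon, 1 selenium; no ring), on a carbon with a double bond to nitrogen. Among the compounds with values here, no measured pair in this set differs in the same way, so the size of this step cannot be read from the data. What the data do show is that the limit is reached by compound 2 and by compound 3, which also carries methylsulfanyl. Compound 4 is therefore expected to sit at or beyond the limit as well, so the expected step that the limit leaves unreadable from compound 2 to compound 4 amounts to no change beyond the scatter. The estimate for compound 4 in this assay is 150000 nM, within a range from 60000 nM to 400000 nM.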

Compound 4, concentration lethal to 50% of the cells: 90100 nM
Compound 4: middle estimate off by 1.7-fold (0.22 log units), on the high side, and the stated range covers the measured number.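

In this assay compound 4 gives 90100 nM as a real number, so the change to methylsulfanyl on a carbon with a double bond to nitrogen can now be set against the selenium-bearing group in a matched pair. Compound 2 remains a limit of the assay, at > 100000 nM and with no number of its own. The pair therefore gives only an at least 1.1-fold lower number from compound 2 to compound 4 (0.04 log units; that floor lies within the scatter) and no evidence of a real difference, and the true size of the step cannot be read: the limit of > 100000 nM in this assay, at which 2 of the 4 values shown sit.

Going by these compounds, how much the swap matters in a pair where both partners give numbers stays open. The compounds shown also do not tell what an amine or a longer chain, such as ethylsulfanyl, would do on this same carbon.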